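The source may report more compounds than this note shows. Statements on the series, on what has been measured and on what is new or still open speak of the compounds shown alone.

Working notes on the series.

Three compounds share a core and differ only in the side chain on the amide-type nitrogen. Compound 1 `CCCNC(=O)Nc1cccc2c1CN(C)CC2c1ccccc1` carries a propylamino group on the carbonyl carbon. In a functional assay on the whole organism for inhibition of sodium-dependent dopamine transporter (Mus musculus) (a higher number here means that more compound is needed for the effect, a lower number that less compound is needed), compound 1 gives only a limit of the assay, > 120 mg/kg, not a number. Compound 2 `CCCCNC(=O)Nc1cccc2c1CN(C)CC2c1ccccc1` carries the butylamino group instead; in this assay compound 2 gives 69 mg/kg. Compound 3 `CCNCC(=O)Nc1cccc2c1CN(C)CC2c1ccccc1` rearranges the same atoms into an (ethylamino)methyl group on the carbonyl carbon, and in this assay compound 3 gives about 60 mg/kg.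

The steps run as follows. The change methyl in place of hydrogen on a saturated chain carbon, three bonds along the chain from an amide-type nitrogen gives an at least 1.7-fold lower number from compound 1 to compound 2 (0.24 log units; that floor lies within the scatter). The change (ethylamino)methyl in place of propylamino on a carbonyl carbon gives an at least 2.0-fold lower number from compound 1 to compound 3 (0.30 log units; that floor lies within the scatter). Between compound 2 and compound 3 the difference of butylamino to (ethylamino)methyl gives a 1.2-fold lower number from compound 2 to compound 3 (0.06 log units; within the scatter). The limit of > 120 mg/kg in this assay, at which 1 of the 3 values shown sits, for compound 1 means only a floor can be stated for the first two steps.

Compound 4 `CC(C)NCC(=O)Nc1cccc2c1CN(C)CC2c1ccccc1` is not yet measured. It differs from compound 3 by methyl in place of hydrogen on a saturated chain carbon bound to an amine nitrogen and a saturated chain carbon. This is the same kind of change as from compound 1 to compound 2, but the surroundings differ: there the methyl entered on a saturated chain carbon, three bonds along the chain from an amide-type nitrogen, here on a saturated chain carbon bound to an amine nitrogen and a saturated chain carbon. The two cores on which the change is made differ by (ethylamino)methyl in place of propylamino on a carbonyl carbon.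

For compound 4 in this assay a step of a 1.3-fold lower number from compound 3 to compound 4 (0.12 log units; within the scatter) is expected, set beside an at least 1.7-fold lower number from compound 1 to compound 2 (0.24 log units; that floor lies within the scatter), which is only a floor and lies within the scatter. The estimate for compound 4 is 45 mg/kg, with a range from 20 mg/kg to 110 mg/kg.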

Compound 4, dose for half-maximal effect: about 30 mg/kg
Compound 4: middle estimate off by 1.5-fold (0.18 log units), on the high side, and the stated range covers the measured number.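

Working notes, continued. In this assay, methyl in place of hydrogen on a saturated chain carbon bound to an amine nitrogen and a saturated chain carbon gives a 2.0-fold lower number from compound 3 to compound 4 (0.30 log units; within the scatter). Neither this step nor the earlier one clears the scatter by itself, so the pair does not show that the change carries from one core to the other, nor that its size depends on the core: the same change on two cores in this assay, an at least 1.7-fold lower number (0.24 log units; that floor lies within the scatter) from compound 1 to compound 2 and a 2.0-fold lower number (0.30 log units; within the scatter) from compound 3 to compound 4; the limit leaves it open whether they differ. Two wider steps do lie beyond the scatter, a 2.3-fold lower number from compound 2 to compound 4 (0.36 log units; beyond the scatter) and an at least 4.0-fold lower number from compound 1 to compound 4 (0.60 log units; beyond the scatter), the second being only a floor; both replace the whole group on the carbonyl carbon rather than add the methyl alone, so they say nothing about the methyl by itself.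

The compounds shown leave open what happens when the isopropyl on the amine nitrogen gives way to a tert-butyl, a cyclopropyl or a longer chain, and whether the number keeps moving in the same direction with such groups. Also open is the true size of the step on the core of compound 1, which rests on a limit: the limit of > 120 mg/kg in this assay, at which 1 of the 4 values shown sits.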